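The source may hold more compounds than are shown below. What is called first, only, known or untested is meant among the compounds shown, and "the series" means these compounds.

Compound 1 `O=C(/C=C/c1ccc([N+](=O)[O-])cc1)Nc1cc2c(Nc3ccc(F)c(Cl)c3)ncnc2cc1O[C@H]1CCOC1` was tested in a functional assay on PC-3 cells (Homo sapiens) for cytotoxicity, read by MTT assay, with a stated time of 72 h (on this read-out higher numbers stand for weaker inhibition and lower numbers for stronger inhibition), where compound 1 gives 22800 nM. Two companions share its core and differ only in the ring at the end of the chain. Compound 2 `COc1cc(/C=C/C(=O)Nc2cc3c(Nc4ccc(F)c(Cl)c4)ncnc3cc2O[C@H]2CCOC2)cc(OC)c1O` gives 26500 nM, and compound 3 `O=C(/C=C/c1cccc(Cl)c1Cl)Nc1cc2c(Nc3ccc(F)c(Cl)c3)ncnc2cc1O[C@H]1CCOC1` gives 27500 nM; the three numbers sit within the scatter of one another, as the steps of a 1.2-fold higher number from compound 1 to compound 2 (0.07 log units; within the scatter) and a 1.2-fold higher number from compound 1 to compound 3 (0.08 log units; within the scatter) show. Compound 4 `O=C(/C=C/c1ccc(F)cc1Cl)Nc1cc2c(Nc3ccc(F)c(Cl)c3)ncnc2cc1O[C@H]1CCOC1` is not yet measured. Its change from compound 1 is 2-chloro-4-fluorophenyl in place of 4-nitrophenyl on a double-bonded chain carbon bound to a double-bonded chain carbon. Both measured steps swap the same 4-nitrophenyl for another substituted phenyl and stay within the scatter, so no step beyond the scatter is expected here either. Compound 4 is therefore estimated at 25000 nM, with a range from 12000 nM to 50000 nM. The expected step is a 1.1-fold higher number from compound 1 to compound 4 (0.04 log units; within the scatter).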

Compound 4, half-maximal inhibitory concentration: 7150 nM
Beside the measured number, compound 4's estimate is 3.5-fold (0.54 log units) above it; the whole stated range lies above it.
By their numbers in this assay, from the lowest: compound 4; then compounds 1, 2 and 3 (each within the scatter of the next).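

At this place on the chain the choice of ring can matter: in this assay the change to 2-chloro-4-fluorophenyl gives a 3.2-fold lower number from compound 1 to compound 4 (0.50 log units; beyond the scatter) as well as a 3.8-fold lower number from compound 3 to compound 4 (0.59 log units; beyond the scatter) and a 3.7-fold lower number from compound 2 to compound 4 (0.57 log units; beyond the scatter) in contrast to the earlier swaps. Carrying chlorine on the phenyl ring is not enough on its own, since 2,3-dichlorophenyl in compound 3 does not share this drop. No measurement at hand explains the difference.

As far as these compounds go, it remains open whether the chlorine, the fluorine or their pairing accounts for the lower number. From the compounds shown here alone, how a pyridine ring or a simple amine would fare at this place also stays unknown.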